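A Lactam Ring in Place of a Fluorinated Piperidine

A few compounds are considered here, and "the series" means these few. Any claim that something is new, unique, unknown or untested is made for them only; others in the source may bear on it.

Compound 2 `O=C1Cc2cc(-c3c(-c4ccc(F)cc4)nc4c(N5CCC(F)CC5)nccn34)ccc2N1` gives 0.7 in an ADME assay on microsomes from liver (Homo sapiens), read by LC-MS, with a stated time of 60 min, tested at 1 uM (a lower number here means that the liver removes a smaller share, a higher number that the liver removes a larger share of the compound in one pass), and stands level with compound 1 `O=C1Cc2cc(-c3c(-c4ccc(F)cc4)nc4c(N5CCC(O)CC5)nccn34)ccc2N1`, which gives 0.7. For the measured compounds named here, the only measured step, no change at the digits printed from compound 1 to compound 2 (within the scatter), is the sole guide for what follows. Compound 3 `O=C1CN(c2nccn3c(-c4ccc5c(c4)CC(=O)N5)c(-c4ccc(F)cc4)nc23)CCN1` differs from compound 2 by 3-oxopiperazin-1-yl in place of 4-fluoropiperidin-1-yl on an aromatic carbon. Because no change at the digits printed from compound 1 to compound 2 (within the scatter) moved nothing beyond the scatter, and no other comparison is on hand, the expected step is small and without a clear direction, so the estimated step a number 0.050 lower from compound 2 to compound 3 (within the scatter) is set near zero. Compound 3 is expected at 0.65, within a range from 0.5 to 0.8.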

Compound 3, hepatic extraction ratio: 0.7
Compound 3: middle estimate off by 0.050, on the low side; the range from low to high includes it.
By their numbers in this assay, from the lowest: compounds 1, 2 and 3 (each within the scatter of the next).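

In this assay, putting 3-oxopiperazin-1-yl in place of 4-fluoropiperidin-1-yl gives no change at the digits printed from compound 2 to compound 3 (within the scatter) and putting it in place of 4-hydroxypiperidin-1-yl gives no change at the digits printed from compound 1 to compound 3 (within the scatter) in the read-out. This position on the aromatic carbon therefore tolerates a ring with a second hetero atom and a hydrogen-bond donor, as well as the earlier swap of the ring substituent, without any step beyond the scatter. Nothing at hand explains why the hepatic extraction ratio stays level. Going by these compounds, whether an open-chain amine or a ring bearing a carboxylic acid at this position would shift it remains open.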